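A few compounds are considered here, and "the series" means these few. Any claim that something is new, unique, unknown or untested is made for them only; others in the source may bear on it.

Measured compounds in this study:

Compound 1 `Cc1cc(C)cc(/C=C(/SCc2ccc(F)cc2)C(=O)c2ccc(Br)cc2)c1` gives in a functional assay on DU-145 cells (Homo sapiens) for inhibition, read by trypan blue exclusion, with a stated time of 96 h (a lower number here means a stronger inhibitor of growth, a higher number a weaker inhibitor of growth), a reading of 10000 nM.
Compound 2 `COc1ccc(C(=O)/C(=C\c2ccc(O)c([N+](=O)[O-])c2)SCc2ccc(Br)cc2)cc1` gives in this assay a reading of 10000 nM.
Compound 3 `O=C(/C(=C\c1ccc([N+](=O)[O-])c(O)c1)SCc1ccc(Br)cc1)C1CCNC1` gives in this assay only a limit, > 100000 nM, and not a number.

Compound 1 thus stands level with compound 2 at the digits shown; the two readings lie within the usual scatter of each other, so nothing separates them. The figure for compound 3 is a limit, recorded as the limit of > 100000 nM in this assay, at which 1 of the 3 values shown sits, and says only that growth inhibition was not reached at that concentration. Among the compounds with values here, no pair of measured compounds differs in a single place, so no measured step is available to anchor a prediction.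

Compound 4 `O=C(/C(=C\c1ccc(Br)cc1)SCc1ccc(F)cc1)c1ccc(Br)cc1` has not yet been measured in this assay. It differs from compound 1 in one place: 4-bromophenyl in place of 3,5-dimethylphenyl on a double-bonded chain carbon bound to a double-bonded chain carbon. Within the data shown here, with no measured step to guide the direction, the change from compound 1 to compound 4 is expected to stay within the scatter, neither clearly stronger nor clearly weaker. The expected step is no change at the digits printed from compound 1 to compound 4 (within the scatter). Compound 4 is therefore estimated at 10000 nM in this assay, with a range from 3000 nM to 40000 nM.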

Compound 4, concentration for 50% growth inhibition: 25000 nM
Beside the measured number, compound 4's estimate is 2.5-fold (0.40 log units) below it, and the stated range covers the measured number.
By their numbers in this assay, from the lowest: compounds 1 and 2 (each within the scatter of the next); then compound 4. At a limit, above all of these: compound 3.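

Replacing 3,5-dimethylphenyl with 4-bromophenyl on a double-bonded chain carbon bound to a double-bonded chain carbon gives, in this assay, a 2.5-fold higher number from compound 1 to compound 4 (0.40 log units; beyond the scatter). Within the data shown here, this is the first measured single-place step, and it shows that the number responds to a change at this position, with the 4-bromophenyl group giving the weaker inhibitor of growth, though only modestly so. The two groups have the same counts of hydrogen-bond donors and acceptors and the same net charge, and both are six-membered aromatic rings of carbon only, so those counts do not distinguish them, and nothing measured here accounts for the step.

The compounds shown leave open how a phenyl ring carrying an amine or a carboxylic acid would read at this position, and whether any such group could bring the number lower than that of compound 1. Among these compounds, they also leave open whether a step of this size would recur on a core other than that of compound 1, since this single pair gives only one reading of the change.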